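Redrawn stereocentres on the 4-methoxycyclohexyl group

The source may hold more compounds than are shown below. What is called first, only, known or untested is meant among the compounds shown, and "the series" means these compounds.

In a functional assay on LNCaP cells (Homo sapiens) for cytotoxicity (a lower number here means a stronger inhibitor, a higher number a weaker inhibitor), compound 1 `CNC(=O)Nc1ccc(-c2nc(N3CC4CCC(C3)O4)c3cnn(CCN(C)C)c3n2)cc1`, carrying 2-(dimethylamino)ethyl, gives 400 nM. Compound 2 `CNC(=O)Nc1ccc(-c2nc(N3CC4CCC(C3)O4)c3cnn(C4CCC5(CC4)OCCCO5)c3n2)cc1` gives 8 nM. Compound 3 `CNC(=O)Nc1ccc(-c2nc(N3CC4CCC(C3)O4)c3cnn([C@H]4CC[C@@H](OC)CC4)c3n2)cc1`, carrying 4-methoxycyclohexyl, gives 1 nM, the lowest of the three. Compound 4 `CNC(=O)Nc1ccc(-c2nc(N3CC4CCC(C3)O4)c3cnn([C@H]4CC[C@H](OC)CC4)c3n2)cc1` has the same atoms and bonds as compound 3: the two compounds have the same atoms and bonds; at least one stereo element is drawn with a configuration in one of them and without one in the other: 2 of 4 stereo elements differ; a stereocentre at a saturated ring carbon is drawn s in compound 3 and r in compound 4; a stereocentre at a saturated ring carbon is drawn s in compound 3 and r in compound 4. The measured steps replace the whole group on the aromatic nitrogen: a 400-fold lower number from compound 1 to compound 3 (2.60 log units; beyond the scatter) is large and an 8.0-fold lower number from compound 2 to compound 3 (0.90 log units; beyond the scatter) is modest. Neither tests stereochemistry alone, so they offer only a rough guide to size. A step toward a higher number is expected, smaller than the modest one: a 3.0-fold higher number from compound 3 to compound 4 (0.48 log units; beyond the scatter). For compound 4 the estimated value is 3 nM, with an expected range of 0.7 nM to 10 nM.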

Compound 4, half-maximal inhibitory concentration: 2 nM
Estimate against measurement, compound 4: 1.5-fold (0.18 log units) above, within the range that was stated.
By their numbers in this assay, from the lowest: compounds 3 and 4 (each within the scatter of the next); then compound 2; then compound 1.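

Redrawing the two stereocentres on the 4-methoxycyclohexyl group gives a 2.0-fold higher number from compound 3 to compound 4 (0.30 log units; within the scatter), so these two compounds are not separated by the configuration at those ring carbons. The advantage over the other groups on the aromatic nitrogen also holds with the redrawn group, with a 4.0-fold lower number from compound 2 to compound 4 (0.60 log units; beyond the scatter) and a 200-fold lower number from compound 1 to compound 4 (2.30 log units; beyond the scatter). The stereo comparison carries one caveat: the fact that one of compounds 3 and 4 is drawn with a defined configuration and the other without, at the place where they differ.

Still open, on these data alone, is whether a hydroxyl or a primary amine in place of the methoxy on the cyclohexyl ring would keep the numbers at this level.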